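Losing one trifluoromethyl from compound 2

The source may hold more compounds than are shown below. What is called first, only, known or untested is meant among the compounds shown, and "the series" means these compounds.

In a functional assay on HeLa cells (Homo sapiens) for inhibition, read by MTT assay, with a stated time of 72 h (on this read-out lower numbers stand for stronger inhibition and higher numbers for weaker inhibition), compound 1 (`COc1cc(NC(C)CCCNC(=O)Nc2cccc(O)c2)c2ncccc2c1`) gives 48000 nM and compound 2 (`COc1cc(NC(C)CCCNC(=O)Nc2cc(C(F)(F)F)cc(C(F)(F)F)c2)c2ncccc2c1`) gives 3100 nM. Compound 2 thus holds the lower of the two numbers, and its gap to compound 1 lies beyond the scatter. Compound 3 (`COc1cc(NC(C)CCCNC(=O)Nc2cccc(C(F)(F)F)c2)c2ncccc2c1`) departs from compound 2 by a single change, hydrogen in place of trifluoromethyl on an aromatic carbon. Going by the values given here, no measured pair shows this change on its own, so the step in this assay has no direct precedent. Compound 3 keeps one trifluoromethyl, and a rise in the number is expected, probably somewhat beyond the scatter, yet the number is expected to stay lower than that of compound 1, which gives 48000 nM. The estimate amounts to an expected 2.6-fold higher number from compound 2 to compound 3 (0.41 log units; beyond the scatter). Compound 3 is estimated at 8000 nM, with an expected range from 3500 nM to 20000 nM.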

Compound 3, half-maximal inhibitory concentration: 14000 nM
For compound 3 the middle estimate is 1.8-fold (0.24 log units) below the measured one; measured number inside the range.
By their numbers in this assay, from the lowest: compound 2; then compound 3; then compound 1.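

In this assay, the second trifluoromethyl proves to matter on its own: hydrogen in its place, on an aromatic carbon meta to a trifluoromethyl group, gives a 4.5-fold higher number from compound 2 to compound 3 (0.65 log units; beyond the scatter). One trifluoromethyl still counts for something, since trifluoromethyl in place of hydroxy on an aromatic carbon gives a 3.4-fold lower number from compound 1 to compound 3 (0.54 log units; beyond the scatter), so compound 3 falls between compound 2 and compound 1 in this assay. No measurement shown here accounts for either step.

The compounds shown leave open whether trifluoromethyl is needed at this carbon or whether another group, such as a chlorine atom, a nitrile or a carboxylic acid, would serve as well. Going by these compounds alone, they also leave open how these steps would hold with a longer chain in place of the one shared by compound 2 and compound 3.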